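Ethylphenyl for Dichlorophenyl on a Cytotoxicity Series

This account rests on a few compounds, and the source may have more. Where it says the series, first, only, none or still open, it means among the compounds named here.

Of the compounds shown here, three sharing one core have been measured in an ADME assay on Huh7.5.1 cells (Homo sapiens) for cytotoxicity, read by ATP content, with a stated time of 48 h; on this read-out higher numbers stand for lower toxicity in this test and lower numbers for higher toxicity in this test. Compound 1 `CC[C@@H]1C[C@H](CC)CN(CCCNC(=O)C2CCN(Cc3nc(-c4ccccc4C)oc3C)CC2)C1` gives 3470 nM, compound 2 `Cc1ccccc1-c1nc(CN2CCC(C(=O)NCCCN3CCC(C(C)C)CC3)CC2)c(C)o1` gives 4280 nM, and compound 3 `Cc1oc(-c2ccc(Cl)c(Cl)c2)nc1CN1CCC(C(=O)NCCCN2C[C@H](C)C[C@H](C)C2)CC1` gives 3170 nM. Compound 3 stands lowest of the three numbers, but its gap to compound 1 and its gap to compound 2 both lie within the scatter, so the three are not separated by this assay.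

The next compound, compound 4 `CCc1ccccc1-c1nc(CN2CCC(C(=O)NCCCN3C[C@H](C)C[C@H](C)C3)CC2)c(C)o1`, departs from compound 3 by 2-ethylphenyl in place of 3,4-dichlorophenyl on an aromatic carbon. Going by the values given here, no measured pair differs only at that aromatic carbon. Among the compounds with values here, the one measured step, a 1.2-fold higher number from compound 1 to compound 2 (0.09 log units; within the scatter), concerns the piperidine end of the molecule and was within the scatter. Compound 1 and compound 2, which carry 2-methylphenyl on that aromatic carbon, and compound 3, which carries 3,4-dichlorophenyl, all sit close together, which suggests that what is attached to the five-membered ring has so far left the read-out in this assay essentially unchanged.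

On that basis compound 4 is expected to show a step of a 1.1-fold higher number from compound 3 to compound 4 (0.04 log units; within the scatter), that is no step beyond the scatter, and its estimated value is 3500 nM, within a range from 1700 nM to 7200 nM.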

Compound 4, half-maximal cytotoxic concentration: 9320 nM
The estimate for compound 4 lay 2.7-fold (0.43 log units) below the measured number; measured number outside the range, above it.
By their numbers in this assay, from the lowest: compounds 3, 1 and 2 (each within the scatter of the next); then compound 4.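

In this assay, going by these compounds alone, the aromatic carbon of the five-membered ring proves able to move the read-out: the swap of 3,4-dichlorophenyl for 2-ethylphenyl gives a 2.9-fold higher number from compound 3 to compound 4 (0.47 log units; beyond the scatter), whereas the only earlier step, a 1.2-fold higher number from compound 1 to compound 2 (0.09 log units; within the scatter), concerned the piperidine end and stayed within the scatter. The earlier impression that this position made no difference therefore does not hold for this change, although the step is modest and rests on a single pair of compounds. The two groups match in the counts available, with 8 heavy atoms each, one six-membered aromatic ring of carbon only and no net charge, so the step goes with an exchange of two chlorine atoms and a changed substitution pattern on that ring, and no measurement here accounts for it.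

Within the data shown here, the single step changes the chlorine atoms and the ethyl group together, so it does not tell which of them goes with the higher number. A 2-chlorophenyl or a 3,4-diethylphenyl group at this aromatic carbon, on the same remaining structure as compound 4, would pull those two parts apart.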